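The source may hold more compounds than are shown below. What is called first, only, known or untested is meant among the compounds shown, and "the series" means these compounds.

Among the compounds with values here, compound 2 `CCOC(=O)c1cnc(-n2nc(C)cc2C)nc1NN1C(=O)C=C(C)C1=O` gives 10000 nM in a functional assay on Jurkat cells for inhibition of nuclear factor NF-kappa-B complex (Homo sapiens) (on this read-out higher numbers stand for weaker inhibition and lower numbers for stronger inhibition), the highest of the two numbers so far; its nearest neighbour is compound 1 `CCOC(=O)c1cnc(-c2ccncc2)nc1NN1C(=O)C=C(C)C1=O`, which gives 6000 nM in this assay. Within the data shown here, the only step on record connects these two: a 1.7-fold higher number from compound 1 to compound 2 (0.22 log units; within the scatter), which exchanged pyridin-4-yl for 3,5-dimethyl-1H-pyrazol-1-yl and stayed within the scatter. Compound 3 `CCOC(=O)c1cnc(-c2cccc(Br)c2)nc1NN1C(=O)C=C(C)C1=O` differs from compound 2 at that same position: 3-bromophenyl in place of 3,5-dimethyl-1H-pyrazol-1-yl on an aromatic carbon. Among the measured compounds shown here, the measured step bears on this change only in part, since it replaced one aromatic substituent at this carbon by another without moving the number beyond the scatter; no step introduces a 3-bromophenyl group or a six-membered aromatic ring of carbon only, so that side of the change has no precedent. For the measured compounds named here, with both numbers so far close together and the one relevant step flat, no step beyond the scatter is expected in this assay in either direction. Compound 3 is therefore expected to give 7000 nM, within 2500 nM to 20000 nM, which corresponds to an expected 1.4-fold lower number from compound 2 to compound 3 (0.15 log units; within the scatter).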

Compound 3, half-maximal inhibitory concentration: 700 nM
Compound 3: the middle estimate sits 10-fold (1.00 log units) above what was measured; measured number below the stated range.
By their numbers in this assay, from the lowest: compound 3; then compounds 1 and 2 (each within the scatter of the next).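

In this assay, the aromatic carbon between two ring nitrogen atoms proves sensitive to the group it carries: 3-bromophenyl in place of 3,5-dimethyl-1H-pyrazol-1-yl gives a 14-fold lower number from compound 2 to compound 3 (1.15 log units; beyond the scatter), and 3-bromophenyl in place of pyridin-4-yl gives an 8.6-fold lower number from compound 1 to compound 3 (0.93 log units; beyond the scatter), whereas the earlier pair gave only a flat step. Of the three groups at this carbon, only 3-bromophenyl has a six-membered aromatic ring of carbon only and a bromine, and it alone separates from the others beyond the scatter, so the series now has a first sign that the choice of aromatic group here matters. No measurement at hand bears on what lies behind this difference.

The compounds shown leave open whether the bromine or the carbon-only ring goes with the lower number, a question that a plain phenyl or a 3-methoxyphenyl at this carbon would bear on. They also leave open whether the same step would hold with a carboxylic acid in place of the ethoxycarbonyl group.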